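The source may hold more compounds than are shown below. What is called first, only, known or untested is meant among the compounds shown, and "the series" means these compounds.

Among the compounds with values here, only two compounds have been tested so far in a functional assay on A-431 cells (Homo sapiens) for inhibition, read by MTT assay, with a stated time of 72 h; a higher number here means a weaker inhibitor, a lower number a stronger inhibitor. Compound 1 (`COc1cc2c(Nc3cccc([N+](=O)[O-])c3)ncnc2c(OC)c1OC`) gives 37700 nM, and compound 2 (`COc1cc2c(Nc3ccc(Br)cc3Cl)ncnc2c(OC)c1OC`) gives 51500 nM. These two numbers lie within the usual scatter of repeated measurements, so compound 2 stands level with compound 1 and neither can be called the better inhibitor.

The next compound is compound 3 (`COc1cc2c(Nc3ccc(Cl)cc3)ncnc2c(OC)c1OC`), in which 4-chlorophenyl takes the place of 4-bromo-2-chlorophenyl on a nitrogen on an aromatic ring (4-chlorophenyl in place of 4-bromo-2-chlorophenyl on a nitrogen on an aromatic ring). Both groups are a six-membered aromatic ring of carbon only, with no net charge.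

Within the data shown here, no measured pair yet shows what a swap of this kind does, so the data give only a weak guide. That guide is the small gap between the two known results, with compound 1 at 37700 nM and compound 2 at 51500 nM. No step beyond the scatter is therefore expected, in either direction. The expected step is a 1.4-fold lower number from compound 2 to compound 3 (0.13 log units; within the scatter), which is an estimate and not a measurement. Compound 3 is estimated at 38000 nM, with an expected range from 14000 nM to 100000 nM.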

Compound 3, half-maximal inhibitory concentration: 19000 nM
Estimate against measurement, compound 3: 2.0-fold (0.30 log units) above, within the range that was stated.
By their numbers in this assay, from the lowest: compounds 3, 1 and 2 (each within the scatter of the next, the first and the last beyond it).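

Within the data shown here, compound 3 gives the first step that lies beyond the scatter: in this assay, there is a 2.7-fold lower number from compound 2 to compound 3 (0.43 log units; beyond the scatter), a modest change. This shows that the number responds to the substituents on the phenyl ring on the nitrogen, even though both groups are a six-membered aromatic ring of carbon only, with no hydrogen-bond donors or acceptors and no net charge; what differs is that 4-bromo-2-chlorophenyl has 8 heavy atoms, including a bromine and a chlorine, while 4-chlorophenyl has 7, with chlorine as its only halogen. Nothing measured here explains why the number falls with this change.

The swap alters more than one feature of the ring at once, so these compounds cannot separate the loss of the bromine from the different arrangement of the halogens. As far as these compounds go, it also remains open how the number would respond to a plain phenyl ring, to a fluorine, an amine or a carboxylic acid on the ring, or to a longer carbon chain in place of the ring.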